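Alkyne aryl swaps on the shared core, growth inhibition

The compounds below may be only part of what the source reports. "The series", "measured", "known", "first", "only" and "open" are said of these compounds alone.

Measured in a functional assay on MCF7 cells (Homo sapiens) for inhibition, read by sulforhodamine B assay, with a stated time of 48 h; on this read-out higher numbers stand for weaker inhibition of growth and lower numbers for stronger inhibition of growth:
Compound 1 `COC(=O)c1sc2cc(C#Cc3ccc(OC)cc3)cnc2c1N` gives 460 nM.
Compound 2 `COC(=O)c1sc2cc(C#Cc3ccccc3F)cnc2c1N` gives only a limit of the assay, > 150000 nM.
Compound 3 `COC(=O)c1sc2cc(C#Cc3cccnc3)cnc2c1N` gives only a limit of the assay, > 150000 nM.

Compound 3 thus stands at the limit of this assay, a limit shared by one other value (the limit of > 150000 nM in this assay, at which 2 of the 3 values shown sit). Two steps ran from a number to that limit: an at least 320-fold higher number from compound 1 to compound 3 (2.51 log units; beyond the scatter) and an at least 320-fold higher number from compound 1 to compound 2 (2.51 log units; beyond the scatter). Between the two limits, a step that the two limits leave unreadable from compound 2 to compound 3. Compound 4 `COC(=O)c1sc2cc(C#Cc3cccc(OC)c3)cnc2c1N` differs from compound 3 by 3-methoxyphenyl in place of pyridin-3-yl on a triple-bonded carbon. For the measured compounds named here, compound 4 carries 3-methoxyphenyl, whereas the only aryl that gave a number, in compound 1, is 4-methoxyphenyl; no measured step covers this swap. Compound 4 is therefore expected somewhere between the two poles, an estimated at least 10-fold lower number from compound 3 to compound 4 (1.00 log units; beyond the scatter) that is readable only if a number is returned. The estimate for compound 4 is 15000 nM, range 500 nM to 150000 nM.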

Compound 4, concentration for 50% growth inhibition: 33400 nM
Compound 4: middle estimate off by 2.2-fold (0.35 log units), on the low side, and the stated range covers the measured number.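

Placing 3-methoxyphenyl on the triple-bonded carbon gives an at least 4.4-fold lower number from compound 3 to compound 4 (0.65 log units; beyond the scatter) and also an at least 4.4-fold lower number from compound 2 to compound 4 (0.65 log units; beyond the scatter) in this small set, so a measurable number at this place is not confined to 4-methoxyphenyl. Compound 2 and compound 3 stay at a limit of the assay, while both methoxyphenyl compounds return numbers. The choice between the two methoxyphenyl groups still matters, with a 73-fold higher number from compound 1 to compound 4 (1.86 log units; beyond the scatter) on the same read-out.

As far as these compounds go, whether the methoxy group itself is needed remains open, since neither an ethoxy group nor an amine on the phenyl ring appears here. The step between compound 2 and compound 3 cannot be read.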